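Replacing the aryl group on the amide of compound 1

A few compounds are considered here, and "the series" means these few. Any claim that something is new, unique, unknown or untested is made for them only; others in the source may bear on it.

Measured in a functional assay on A549 cells (Homo sapiens) for cytotoxicity, read by MTT assay, with a stated time of 72 h; a lower number here means a stronger inhibitor, a higher number a weaker inhibitor:
Compound 1 `O=C(CN1CCN(c2nnc(Cc3ccccc3)c3ccccc23)CC1)Nc1ccc(F)c(C(F)(F)F)c1`: 2480 nM
Compound 2 `O=C(CN1CCN(c2nnc(Cc3ccncc3)c3ccccc23)CC1)Nc1ccc(F)c(C(F)(F)F)c1`: 16000 nM

Compound 1 holds the lower of these two numbers in this assay. Among the measured compounds shown here, the only measured step, a 6.5-fold higher number from compound 1 to compound 2 (0.81 log units; beyond the scatter), puts pyridin-4-yl in place of phenyl on a saturated chain carbon bound to an aromatic carbon. Compound 3 `O=C(CN1CCN(c2nnc(Cc3ccccc3)c3ccccc23)CC1)Nc1ccc(Br)cc1` instead changes the group on the amide-type nitrogen, with 4-bromophenyl in place of 4-fluoro-3-(trifluoromethyl)phenyl (4-bromophenyl in place of 4-fluoro-3-(trifluoromethyl)phenyl on an amide-type nitrogen). For the measured compounds named here, no measured step touches that group, so the data give neither size nor direction for this change, and no step beyond the scatter is expected. The estimated step is a 1.2-fold higher number from compound 1 to compound 3 (0.08 log units; within the scatter), though with wide uncertainty. For compound 3 the expected value is 3000 nM, with an estimated range of 900 nM to 10000 nM.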

Compound 3, half-maximal inhibitory concentration: 2000 nM
Compound 3: the middle estimate sits 1.5-fold (0.18 log units) above what was measured; the measured number falls inside the stated range.
By their numbers in this assay, from the lowest: compounds 3 and 1 (each within the scatter of the next); then compound 2.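

The group on the amide-type nitrogen now has its first measured step: in this assay the change is a 1.2-fold lower number from compound 1 to compound 3 (0.09 log units; within the scatter) and so gives no measurable separation between 4-bromophenyl and 4-fluoro-3-(trifluoromethyl)phenyl. A single bromine can therefore stand in for the fluorine and trifluoromethyl pair on this aromatic ring without a step beyond the scatter. Nothing measured on these compounds accounts for this result.

Both groups are halogen-bearing phenyl rings, so the data leave open whether a cyclohexyl group on this nitrogen, or a carboxylic acid or an amine on the phenyl ring, would keep the number in this range.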